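The source may hold more compounds than are shown below. What is called first, only, known or untested is meant among the compounds shown, and "the series" means these compounds.

In an ADME assay on S9 fraction from liver (Rattus norvegicus) for metabolic stability, read by LC-MS, using NADPH, with a stated time of 30 min (a higher number here means that more of the compound is left, a lower number that less of the compound is left), compound 1 `CCCCCCCCc1ccc(OCC(=O)Cn2nnc(C)n2)cc1` gives < 5% as a limit of the assay, not a number. Compound 2 `CCCCCCCCc1ccc(OCC(=O)Cn2nnc(CCC(=O)O)n2)cc1` gives < 5% which is also a limit. Compound 3 `CCCCCCCCc1ccc(OCC(=O)Cn2nnc(-c3cccc(C(=O)O)c3)n2)cc1` gives < 5% which is a limit too. For the measured compounds named here, neither a step that the two limits leave unreadable from compound 1 to compound 2 nor a step that the two limits leave unreadable from compound 1 to compound 3 nor a step that the two limits leave unreadable from compound 2 to compound 3 has a size that can be read, though all three compounds stand together at the limit of < 5% in this assay, at which 3 of the 3 values shown sit, as the only firm guide. Compound 4 `CCCCCCCCc1ccc(OCC(=O)Cn2nnnc2SC)cc1` changes the group on the saturated chain carbon bound to a carbonyl carbon, as 5-(methylsulfanyl)-1H-tetrazol-1-yl in place of 5-methyl-2H-tetrazol-2-yl on a saturated chain carbon bound to a carbonyl carbon shows, and keeps the rest of the core of compound 1. No size can therefore be carried over, and a step that the limit leaves unreadable from compound 1 to compound 4 is expected to lie within the usual scatter. Compound 4 is estimated at 3% with an expected range from 1% to 12% in this assay when measured.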

Compound 4, percent of the compound remaining: 21%
Compound 4: the middle estimate sits 18 percentage points below what was measured, and the stated range ends below it.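

In this assay, 5-(methylsulfanyl)-1H-tetrazol-1-yl in place of 5-methyl-2H-tetrazol-2-yl on a saturated chain carbon bound to a carbonyl carbon gives a number at least 16 percentage points higher from compound 1 to compound 4 (beyond the scatter). The steps among compound 1, compound 2 and compound 3 cannot be read, so this is the first change of this group with a readable size, and the other compounds remain at a limit of the assay: the limit of < 5% in this assay, at which 3 of the 4 values shown sit.

On these data alone, whether the step follows the methylsulfanyl group or the 1H-tetrazol-1-yl attachment stays open, and 5-methyl-1H-tetrazol-1-yl would separate the two. As far as these compounds go, how an amine on the tetrazole would read also stays open.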